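The compounds below may be only part of what the source reports. "The series", "measured", "known", "first", "only" and "open" are said of these compounds alone.

Measured in an ADME assay for permeability, using PAMPA, with a stated time of 30 min, at pH 7.4; a higher number here means that the compound crosses the layer faster, a lower number that the compound crosses the layer more slowly:
compound 1 `CC(C)Cc1ccc2c(NCCCNCc3ccco3)ccnc2c1` gives 23 10^-6 cm/s.
compound 2 `c1ccc(Oc2ccc3c(NCCCNCc4ccco4)ccnc3c2)cc1` gives 317 10^-6 cm/s.
compound 3 `COc1ccc(F)cc1CNCCCNc1ccnc2cc(CC(C)C)ccc12` gives 23 10^-6 cm/s.

Between compound 1 and compound 2 the only change is phenoxy in place of isobutyl on an aromatic carbon. That change made a large step, a 14-fold higher number from compound 1 to compound 2 (1.14 log units; beyond the scatter).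

Compound 3 differs from compound 1 only in the group carried on the chain carbon bound to the amine nitrogen: 5-fluoro-2-methoxyphenyl in place of furan-2-yl on a saturated chain carbon bound to an amine nitrogen. In this assay this made no change at the digits printed from compound 1 to compound 3 (within the scatter), so compound 3 and compound 1 stand level, together the lowest of the three numbers, with compound 2 well above both.

Compound 4 `COc1ccc(F)cc1CNCCCNc1ccnc2cc(Oc3ccccc3)ccc12` is not yet measured. It stands to compound 3 as compound 2 stands to compound 1: phenoxy in place of isobutyl on an aromatic carbon. The place is the same in every word, so this is the same change made a second time, now on the core of compound 3 instead of the core of compound 1.

For compound 4 in this assay the step of a 13-fold higher number from compound 3 to compound 4 (1.12 log units; beyond the scatter) is expected, set beside a 14-fold higher number from compound 1 to compound 2 (1.14 log units; beyond the scatter). This rests on one pairing only, and on the fact that the two cores start from the same level because no change at the digits printed from compound 1 to compound 3 (within the scatter); with a single precedent the range is kept wide. The estimate for compound 4 is 300 10^-6 cm/s, expected to fall between 110 10^-6 cm/s and 750 10^-6 cm/s.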

Compound 4, apparent permeability: 317 10^-6 cm/s
Compound 4: middle estimate off by 1.1-fold (0.02 log units), on the low side, and the stated range covers the measured number.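

In this assay, phenoxy in place of isobutyl on an aromatic carbon carried over from one core to the other, with a 14-fold higher number from compound 3 to compound 4 (1.14 log units; beyond the scatter) matching the earlier step: the same change on two cores in this assay, a 14-fold higher number (1.14 log units; beyond the scatter) from compound 1 to compound 2 and a 14-fold higher number (1.14 log units; beyond the scatter) from compound 3 to compound 4, 1.0-fold (0.00 log units) apart, within the scatter of two such steps. The other change, 5-fluoro-2-methoxyphenyl in place of furan-2-yl on the saturated chain carbon, also held once phenoxy was present, with no change at the digits printed from compound 2 to compound 4 (within the scatter): the same change on two cores in this assay, no change at the digits printed (within the scatter) from compound 1 to compound 3 and no change at the digits printed (within the scatter) from compound 2 to compound 4, 1.0-fold (0.00 log units) apart, within the scatter of two such steps. Within these four compounds the two changes therefore read as independent of each other, but this rests on a single square of two cores in one assay, so it gives no reason for the size of the phenoxy step and does not show that the step would transfer to any core outside this set.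

On these data alone, it remains open whether other groups on the same aromatic carbon, such as a methoxy group, a cyclohexyl ring or a benzyloxy group, would give a step like that of phenoxy. As far as these compounds go, it also remains open whether the agreement would hold with a longer chain joining the two amine nitrogens, or with an amide in place of the secondary amine on that chain.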